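This account rests on a few compounds, and the source may have more. Where it says the series, first, only, none or still open, it means among the compounds named here.

Working notes on the sulfonyl-piperidine series, read in an ADME assay on HCT-116 cells (Homo sapiens) for cytotoxicity, read by CellTiter-Glo, with a stated time of 72 h; on this read-out higher numbers stand for weaker inhibition and lower numbers for stronger inhibition.

Compound 1 `Cc1nc(Cl)sc1S(=O)(=O)N1CCC(N2CCC(C)CC2)CC1` carries a 2-chloro-4-methyl-1,3-thiazol-5-yl group on the sulfonyl sulfur. In this assay compound 1 gives > 10000 nM, which is a limit of the assay and not a number. Compound 1 therefore sits at the limit of > 10000 nM in this assay, at which 1 of the 3 values shown sits, the weakest end of what has been seen so far, in the sense that no number was reached for it.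

Compound 2 `COc1ccc(Br)cc1S(=O)(=O)N1CCC(N2CCC(C)CC2)CC1` gives > 5000 nM in this assay, again a limit. Compound 3 `CC1CCN(C2CCN(S(=O)(=O)c3ccc(-c4ccccc4F)cc3)CC2)CC1` gives > 5000 nM in this assay, also a limit. Both of these stand at the limit of > 5000 nM in this assay, at which 2 of the 3 values shown sit. Among the compounds with values here, with every value a limit, no step between measured compounds can be sized, and no ordering among compounds 1, 2 and 3 can be stated.

Compound 4 `CC1CCN(C2CCN(S(=O)(=O)c3cccc(Cl)c3)CC2)CC1` differs from compound 1 by 3-chlorophenyl in place of 2-chloro-4-methyl-1,3-thiazol-5-yl on a sulfonyl sulfur. Within the data shown here, the three aryl and heteroaryl sulfonyl groups seen so far, including the one in compound 1 at > 10000 nM, have all left this assay at a limit, so the step from compound 1 to compound 4 is expected to be none beyond the scatter, a step that the limit leaves unreadable from compound 1 to compound 4. For compound 4 the estimate is 15000 nM, with a range from 5000 nM to 50000 nM, and most likely the assay will again report only a limit.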

Compound 4, half-maximal inhibitory concentration: > 5000 nM
Compound 4: only a limit was reported; the forecaster's own chance of this, stated with the estimate: 85%; the middle value lies beyond the limit too.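

In this assay compound 4 gives > 5000 nM and this is a limit of the assay, not a number. Within the data shown here, compound 1 also stands at a limit, so no step between compound 1 and compound 4 can be read. The compounds shown leave open whether any sulfonyl group on the shared core reaches a measured number in this assay and how the four compounds rank.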